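The compounds below may be only part of what the source reports. "The series", "measured", "known", "first", "only" and "open" are said of these compounds alone.

Compound 1 `CCCSc1nc(N/N=C/c2ccc(Cl)cc2)c2nnn(Cc3ccccc3)c2n1` gives > 64000 nM in a functional assay on ECa-109 cells (Homo sapiens) for antiproliferative activity, read by MTT assay, with a stated time of 72 h; a higher number here means a weaker inhibitor, a lower number a stronger inhibitor; compound 2 `CCCSc1nc(N/N=C/c2ccc([N+](=O)[O-])cc2)c2nnn(Cc3ccccc3)c2n1` gives 6640 nM; compound 3 `CCCSc1nc(N/N=C/c2c[nH]c3ccccc23)c2nnn(Cc3ccccc3)c2n1` gives 8690 nM.

The value of compound 1 is a limit of the assay and not a number; it sits at the limit of > 64000 nM in this assay, at which 1 of the 3 values shown sits. Two measured steps lead away from compound 1: an at least 9.6-fold lower number from compound 1 to compound 2 (0.98 log units; beyond the scatter) and an at least 7.3-fold lower number from compound 1 to compound 3 (0.86 log units; beyond the scatter). Between the other two, a 1.3-fold higher number from compound 2 to compound 3 (0.12 log units; within the scatter), so no order can be read there.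

Compound 4 `CCCSc1nc(N/N=C(\C)c2ccccc2O)c2nnn(Cc3ccccc3)c2n1` differs from compound 1 in one place: a group of 10 heavy atoms (8 carbon, 1 nitrogen, 1 oxygen; one six-membered aromatic ring of carbon only) in place of a group of 9 heavy atoms (7 carbon, 1 nitrogen, 1 chlorine; one six-membered aromatic ring of carbon only), on a nitrogen on an aromatic ring. Both measured departures from the 4-chlorophenyl group brought at least modest lower numbers, so a lower number is expected here too, estimated as an at least 5.3-fold lower number from compound 1 to compound 4 (0.72 log units; beyond the scatter). The estimate for compound 4 in this assay is 12000 nM, within a range from 3000 nM to 64000 nM.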

Compound 4, half-maximal inhibitory concentration: 11100 nM
Estimate against measurement, compound 4: 1.1-fold (0.03 log units) above; measured number inside the range.
By their numbers in this assay, from the lowest: compounds 2, 3 and 4 (each within the scatter of the next). At a limit, above all of these: compound 1.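

In this assay, a group carrying a hydrogen-bond donor and no chlorine, replacing a group with no donor, gives an at least 5.7-fold lower number from compound 1 to compound 4 (0.76 log units; beyond the scatter). This is a third departure from compound 1 at this place, and it too ends in a lower number, now with a change on a nitrogen on an aromatic ring that keeps the carbon-only aromatic ring. The step has no upper size, because compound 1 stands at a limit: the limit of > 64000 nM in this assay, at which 1 of the 4 values shown sits.

The compounds shown leave open whether the donor or the loss of chlorine carries this step. On these data alone, how an amine or a carboxylic acid on this aromatic ring would read also remains open.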